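This account rests on a few compounds, and the source may have more. Where it says the series, first, only, none or still open, it means among the compounds named here.

In a functional assay on Mahlavu cells (Homo sapiens) for antiproliferative activity, read by sulforhodamine B assay, with a stated time of 72 h (on this read-out lower numbers stand for stronger inhibition and higher numbers for weaker inhibition), compound 1 `Cc1cc(C)cc(COc2ccc(-c3cc(CN4CCN(Cc5ccc(C(F)(F)F)cc5)CC4)no3)cc2)c1` gives 6000 nM, compound 2 `N#Cc1ccccc1COc1ccc(-c2cc(CN3CCN(Cc4ccc(C(F)(F)F)cc4)CC3)no2)cc1` gives 3500 nM and compound 3 `N#Cc1cccc(COc2ccc(-c3cc(CN4CCN(c5ccc(C(F)(F)F)cn5)CC4)no3)cc2)c1` gives 1300 nM. Among the compounds with values here, the only single-point step among them, a 1.7-fold lower number from compound 1 to compound 2 (0.23 log units; within the scatter), concerns the group on the saturated chain carbon bound to the oxygen on the aromatic ring and stays within the scatter. Compound 3 holds the lowest of the three numbers; its gap to compound 2 and its gap to compound 1 both lie beyond the scatter, but compound 3 differs from compound 2 in two places at once, so the values alone show that compound 3 is the more potent of the pair without tracing the effect to one change.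

Compound 4 `N#Cc1cccc(COc2ccc(-c3cc(CN4CCN(CC5CCCO5)CC4)no3)cc2)c1` differs from compound 3 by (oxolan-2-yl)methyl in place of 5-(trifluoromethyl)pyridin-2-yl on an amine nitrogen in a ring. Within the data shown here, no measured step touches this amine nitrogen in a ring, so nothing here calibrates the change. Compounds 1 and 2, which carry a saturated chain on that nitrogen rather than an aromatic ring, sit at the weaker end, so the expectation for compound 4 is a move to a higher number, a 3.1-fold higher number from compound 3 to compound 4 (0.49 log units; beyond the scatter), with wide uncertainty. Compound 4 is therefore expected to give about 4000 nM in this assay, within a range of 1500 nM to 12000 nM.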

Compound 4, half-maximal inhibitory concentration: 4800 nM
For compound 4 the middle estimate is 1.2-fold (0.08 log units) below the measured one, and the stated range covers the measured number.
By their numbers in this assay, from the lowest: compound 3; then compounds 2, 4 and 1 (each within the scatter of the next).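

In this assay, within the data shown here, this is the first step that touches the amine nitrogen in a ring: a 3.7-fold higher number from compound 3 to compound 4 (0.57 log units; beyond the scatter), on exchanging 5-(trifluoromethyl)pyridin-2-yl for (oxolan-2-yl)methyl. It shows that the number responds to what this nitrogen carries, and that this pair favours the 5-(trifluoromethyl)pyridin-2-yl group, even though the counts of hydrogen-bond donors and acceptors printed for the two groups are the same, so those counts do not separate them. The exchange alters several things together, replacing a six-membered aromatic ring with a five-membered non-aromatic ring, removing the trifluoromethyl and lowering the heavy-atom count, and nothing available explains the size or direction of the step.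

Which of these differences carries the step remains open, and a plain pyridin-2-yl without the trifluoromethyl, a phenyl or an open-chain 2-methoxyethyl on the same nitrogen would begin to separate them. From the compounds shown here alone, it is also open whether the same exchange would give a similar step with 3,5-dimethylphenyl or 2-cyanophenyl on the saturated chain carbon at the other end of the molecule.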